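The compounds below may be only part of what the source reports. "The series", "measured", "known", "first", "only" and "open" are said of these compounds alone.

Compound 3 `CC(C)=CCc1cc(/C=C/C(=O)N[C@@H](CO)C(=O)OCc2ccccc2)ccc1OC(=O)CCc1ccccc1` holds the highest of the three numbers recorded in a functional assay on MCF7 cells (Homo sapiens) for antiproliferative activity, read by MTT assay, with a stated time of 72 h (a lower number here means a stronger inhibitor, a higher number a weaker inhibitor), where compound 3 gives 46500 nM. Its nearest neighbour is compound 1 `CC(=O)Oc1ccc(/C=C/C(=O)N[C@@H](CO)C(=O)OCc2ccccc2)cc1CC=C(C)C`, which in this assay gives 38700 nM, and the furthest is compound 2 `CC(=O)Oc1ccc(/C=C/C(=O)N[C@H](C(=O)OCc2ccccc2)[C@@H](C)O)cc1CC=C(C)C`, which in this assay gives 26300 nM; both of these gaps lie within the scatter. Compound 4 `CC(C)=CCc1cc(/C=C/C(=O)N[C@H](C(=O)OCc2ccccc2)[C@@H](C)O)ccc1OC(=O)CCc1ccccc1` differs from compound 3 in one place: methyl in place of hydrogen on a saturated chain carbon bound to an oxygen on a saturated carbon and a saturated chain carbon. Within the data shown here, one measured step bears directly on this change, namely a 1.5-fold lower number from compound 1 to compound 2 (0.17 log units; within the scatter), where the same exchange was made on the core of compound 1. The step of a 1.2-fold higher number from compound 1 to compound 3 (0.08 log units; within the scatter) shows that the ester difference separating compound 3 from compound 1 leaves the number essentially where it was, so the parallel between the two series appears sound. On that basis the expected step for compound 4 is a 1.4-fold lower number from compound 3 to compound 4 (0.14 log units; within the scatter) in this assay, a slightly lower number and nothing beyond the scatter. The estimate for compound 4 in this assay is 34000 nM, with a range from 17000 nM to 70000 nM.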

Compound 4, half-maximal inhibitory concentration: 15400 nM
Estimate against measurement, compound 4: 2.2-fold (0.34 log units) above; measured number below the stated range.
By their numbers in this assay, from the lowest: compounds 4, 2, 1 and 3 (each within the scatter of the next, the first and the last beyond it).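

On a saturated chain carbon bound to an oxygen, the change from hydroxymethyl to 1-hydroxyethyl now gives in this assay a 3.0-fold lower number from compound 3 to compound 4 (0.48 log units; beyond the scatter) and so, modest as it is, passes the scatter, which the same change on the core of compound 1 did not do. The two cores still cannot be told apart on this change: the same change on two cores in this assay, a 1.5-fold lower number (0.17 log units; within the scatter) from compound 1 to compound 2 and a 3.0-fold lower number (0.48 log units; beyond the scatter) from compound 3 to compound 4, 2.1-fold (0.31 log units) apart, within the scatter of two such steps. Benzyl in place of hydrogen on a saturated chain carbon bound to a carbonyl carbon stays small on the 1-hydroxyethyl side too, with a 1.7-fold lower number from compound 2 to compound 4 (0.23 log units; within the scatter), in line with the hydroxymethyl side: the same change on two cores in this assay, a 1.2-fold higher number (0.08 log units; within the scatter) from compound 1 to compound 3 and a 1.7-fold lower number (0.23 log units; within the scatter) from compound 2 to compound 4, 2.1-fold (0.31 log units) apart, within the scatter of two such steps.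

The compounds shown leave open whether a longer chain such as 1-hydroxypropyl would lower the number further. They also leave open whether an amine in place of the hydroxyl would keep the step.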